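Aryl ether swap at the triazole methylene in compound 1

The source may hold more compounds than are shown below. What is called first, only, known or untested is meant among the compounds shown, and "the series" means these compounds.

Measured so far in a functional assay on HepG2 cells (Homo sapiens) for cytotoxicity, read by MTT assay, with a stated time of 48 h; a higher number here means a weaker inhibitor, a lower number a stronger inhibitor:
compound 1, `COC(=O)c1ccccc1OCc1cn(-c2ccc(S(=O)(=O)N3CCc4ccccc4C3)cc2)nn1`, gives 12400 nM
compound 2, `COc1cc2c(cc1OC)CN(S(=O)(=O)c1ccc(-n3cc(COc4ccc(C=O)cc4)nn3)cc1)CC2`, gives 12500 nM
compound 3, `COc1cc2c(cc1OC)CN(S(=O)(=O)c1ccc(-n3cc(COc4ccc5ccccc5c4)nn3)cc1)CC2`, gives 1260 nM

Compound 1 stands second highest of the three numbers in this assay; compound 2 lies within the scatter of it, while compound 3 is the only one clearly apart from it. Within the data shown here, the sole step that is measured beyond the scatter is a 9.9-fold lower number from compound 2 to compound 3 (1.00 log units; beyond the scatter), which changes the aryl ether but does not touch the change considered here.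

Compound 4, `O=Cc1ccc(OCc2cn(-c3ccc(S(=O)(=O)N4CCc5ccccc5C4)cc3)nn2)cc1`, differs from compound 1 by 4-formylphenyl in place of 2-(methoxycarbonyl)phenyl on an oxygen on a saturated carbon. Among the measured compounds shown here, no measured step covers this exact swap. What bears on it is compound 2, which carries the same 4-formylphenyl on the same oxygen and gives 12500 nM, within the scatter of compound 1 at 12400 nM, although compound 2 also carries two methoxy groups on the shared core that compound 4 lacks. On that basis no step beyond the scatter is expected: the estimated change is a 1.0-fold higher number from compound 1 to compound 4 (0.00 log units; within the scatter). Compound 4 is expected at 12500 nM, in the range 5500 nM to 28000 nM.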

Compound 4, half-maximal inhibitory concentration: 5270 nM
Compound 4: middle estimate off by 2.4-fold (0.38 log units), on the high side; measured number outside the range, below it.
By their numbers in this assay, from the lowest: compound 3; then compound 4; then compounds 1 and 2 (each within the scatter of the next).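

In this assay, the aryl ether on the core of compound 1 is not indifferent to this swap: 4-formylphenyl in place of 2-(methoxycarbonyl)phenyl gives a 2.4-fold lower number from compound 1 to compound 4 (0.37 log units; beyond the scatter). The same 4-formylphenyl ether also reads differently on the two cores, with compound 2, which carries two methoxy groups, at 12500 nM and compound 4, which lacks them, at 5270 nM, so the value of this group cannot be carried from one core to the other. Nothing available accounts for the step from compound 1 to compound 4.

Still open, going by these compounds, is whether the step follows from the formyl group or from the loss of the methoxycarbonyl group, which a phenyl ether bearing a carboxylic acid or an amine in place of the formyl would help separate. Also open, on these data alone, is whether naphthalen-2-yl on the core of compound 4 repeats a 9.9-fold lower number from compound 2 to compound 3 (1.00 log units; beyond the scatter).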